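This account rests on a few compounds, and the source may have more. Where it says the series, first, only, none or still open, it means among the compounds named here.

Measured in a functional assay on RAW264.7 cells (Mus musculus) for inhibition, read by Griess assay, with stated times of 3 h and 24 h; a lower number here means a stronger inhibitor, a higher number a weaker inhibitor:
- Compound 1 `C=C1CCC2[C@](C)(CO)[C@H](O)CC[C@@]2(C)[C@@H]1CCn1cncn1`: > 100000 nM
- Compound 2 `C=C1CCC2[C@](C)(CO)[C@H](O)CC[C@@]2(C)[C@@H]1CCOc1ccc(-c2cc(=O)c3cc(C)ccc3o2)cc1`: > 100000 nM

Compound 2 gives only a limit of the assay, > 100000 nM, and not a number. Compound 1 likewise gives only a limit, > 100000 nM. Among the compounds with values here, the series so far therefore rests on (the limit of > 100000 nM in this assay, at which 2 of the 2 values shown sit).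

Compound 3 `C=C1CCC2[C@](C)(CO)[C@H](O)CC[C@@]2(C)[C@@H]1CCOc1ccc(Br)cc1` differs from compound 2 in one place: one bromine atom in place of a group of 12 heavy atoms (10 carbon, 2 oxygen; one six-membered aromatic ring of carbon only, one six-membered aromatic ring with 1 hetero atom), on an aromatic carbon. The bromo group enters on an aromatic carbon of a six-membered aromatic ring of carbon only.

Within the data shown here, no measured step shows what such an exchange does in this assay. A small move towards stronger inhibition is expected, not clearly beyond the scatter, with a reported limit again quite possible. The expected step is an at least 1.6-fold lower number from compound 2 to compound 3 (0.22 log units; that floor lies within the scatter). Compound 3 is estimated at 60000 nM, with an expected range of 12000 nM to 120000 nM.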

Compound 3, half-maximal inhibitory concentration: 40300 nM
For compound 3 the middle estimate is 1.5-fold (0.17 log units) above the measured one, within the range that was stated.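

In this assay, compound 3 is the first compound shown to give a number and not a limit, so a change on this aromatic carbon can bring the read-out off the limit. One bromine atom in place of the group of 12 heavy atoms gives an at least 2.4-fold lower number from compound 2 to compound 3 (0.39 log units; beyond the scatter), and 4-bromophenoxy in place of 1H-1,2,4-triazol-1-yl on the saturated chain gives an at least 2.4-fold lower number from compound 1 to compound 3 (0.39 log units; beyond the scatter). Both steps are only lower bounds on their size, since the other two compounds give no number: the limit of > 100000 nM in this assay, at which 2 of the 3 values shown sit.

The compounds shown leave open whether bromo is needed at this place, or whether a chloro or methoxy group would serve as well. They also leave open what an amine or a carboxylic acid there, or a longer chain carrying the 4-bromophenoxy group, would do.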